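Mirror-Image Test of a Potent Sigma Ligand

The source may report more compounds than this note shows. Statements on the series, on what has been measured and on what is new or still open speak of the compounds shown alone.

Of the compounds shown here, three have been measured in an assay on cell membranes for displacement of a labelled ligand from Sigma non-opioid intracellular receptor 1 (Cavia porcellus), read by scintillation counting; on this read-out higher numbers stand for weaker inhibition and lower numbers for stronger inhibition. Among the measured compounds shown here, compound 1 `CCNC(C)c1cc2c(cc1OC)OC(C)(C)C=C2` gives 83 nM, and compound 2 `CCN(CC)CCCC(C)NC(C)c1cc2c(cc1OC)OC(C)(C)C=C2` gives 192 nM; the step of a 2.3-fold higher number from compound 1 to compound 2 (0.36 log units; beyond the scatter) is the only measured change between neighbours, and it concerns a substituent on the amine-bearing carbon. Compound 3 `COc1cc2c(cc1[C@H](C)N(C)Cc1ccccc1)C=CC(C)(C)O2` gives 2.8 nM in this assay, the lowest of the three numbers, which marks it as the strongest binder, with compound 1 nearest and compound 2 furthest away. Compound 4 `COc1cc2c(cc1[C@@H](C)N(C)Cc1ccccc1)C=CC(C)(C)O2` differs from compound 3 only in configuration: the two compounds have the same atoms and bonds and differ only in configuration as drawn: 1 of 1 stereo elements differ; a stereocentre at a saturated chain carbon is drawn S in compound 3 and R in compound 4. For the measured compounds named here, no measured step speaks to a change of configuration, since the step from compound 1 to compound 2 alters a group rather than the arrangement at a stereocentre. Mirror-image pairs can give like or unlike numbers, and with nothing measured to set the size, the expected step is a 3.2-fold higher number from compound 3 to compound 4 (0.51 log units; beyond the scatter), a moderate weakening with wide uncertainty. Compound 4 is therefore estimated at 9 nM, within a range from 2.5 nM to 40 nM.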

Compound 4, inhibition constant: 4.5 nM
Compound 4: the middle estimate sits 2.0-fold (0.30 log units) above what was measured; the measured number falls inside the stated range.
By their numbers in this assay, from the lowest: compounds 3 and 4 (each within the scatter of the next); then compound 1; then compound 2.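

Turning the stereocentre at the saturated chain carbon from S to R gives a 1.6-fold higher number from compound 3 to compound 4 (0.21 log units; within the scatter) in this assay, so the two mirror-image arrangements cannot be told apart on this read-out. Among the compounds shown here, this is the first measured step that concerns configuration alone, since the earlier step exchanged a group, and it shows that with this set of groups, the arrangement at this carbon has no effect beyond the scatter. The comparison is a clean one, because nothing else separates the pair: the fact that compounds 3 and 4 differ only in the configuration as drawn

From the compounds shown here alone, what stays open is whether this holds only for these two compounds, or also for the mirror images of compound 1 and compound 2. Going by these compounds, it is also open whether the arrangement at this carbon would matter in a compound carrying a longer chain or a carboxylic acid there.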